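Adding a Methyl to a Phenyl Ring: An Expected Outcome

This account rests on a few compounds, and the source may have more. Where it says the series, first, only, none or still open, it means among the compounds named here.

Compound 1, `COc1ccccc1NC(=O)c1ccc(OCCCN2CCN(c3ccccc3OC)CC2)cc1`, gives 79.4 nM in an assay on Prostate gland (Oryctolagus cuniculus) for inhibition of Adrenergic receptor alpha-1 (Homo sapiens); on this read-out lower numbers stand for tighter binding and higher numbers for weaker binding.
Compound 2, `COc1ccccc1N1CCN(CCC(Oc2ccc(NC(=O)c3ccccc3OCCCC(=O)O)cc2)c2ccccc2)CC1`, gives 79.4 nM in this assay.

On the numbers shown, compound 2 stands level with compound 1 at the digits given; the two values lie within the usual scatter of this kind of measurement, so nothing can be said about an order between them. Going by the values given here, the two compounds differ in many places at once, and no single step between them has been worked out, so the shared value says only that both sit at the same level.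

Compound 3, `COc1ccccc1N1CCN(CCC(Oc2ccc(NC(=O)c3ccccc3OCCCC(=O)O)cc2)c2ccc(C)cc2)CC1`, is compound 2 with one change: methyl in place of hydrogen on an aromatic carbon. Among the measured compounds there is no pair that differs by this change alone, so no measured step can guide the expectation. A change of one carbon on the outer edge of the molecule is expected to move the result in this assay little, if at all, and in no particular direction beyond the scatter. The expected step of a 1.0-fold lower number from compound 2 to compound 3 (0.00 log units; within the scatter) is therefore estimated as no change beyond the scatter. For compound 3 the estimated dissociation constant is 79 nM, with an expected range from 25 nM to 250 nM.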

Compound 3, dissociation constant: 79.4 nM
Compound 3: the middle estimate sits 1.0-fold (0.00 log units) below what was measured; the measured number falls inside the stated range.
By their numbers in this assay, from the lowest: compounds 1, 2 and 3 (each within the scatter of the next).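

Methyl in place of hydrogen on an aromatic carbon, para to a large group, brings no change at the digits printed from compound 2 to compound 3 (within the scatter) in this assay. Going by these compounds alone, compounds 1 and 2 differ in many places at once, so their shared level could not be tied to any one feature, whereas this pair differs in one place only and gives the first direct reading of a single change: going from phenyl to 4-methylphenyl leaves the binding number where it was, so this position takes one added carbon without a shift that can be told from the scatter. No other measurement accompanies this result, so the data offer no explanation for the absence of a change.

Going by these compounds, a single methyl is only one small test of this position, so it remains open whether an amine, a carboxylic acid or a longer chain in the same place would also leave the number unchanged or would move it in either direction. On these data alone, it is also open whether a methyl on another carbon of this ring, or on one of the other aromatic rings in the molecule, would give the same flat result.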